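The source may hold more compounds than are shown below. What is called first, only, known or untested is meant among the compounds shown, and "the series" means these compounds.

Compound 2 `COc1ccc(C2=NN(C3=NC(=O)/C(=C4\C(=O)Nc5ccccc54)S3)C(c3ccc(Cl)cc3)C2)cc1` gives 77500 nM in a functional assay on cells (Cancer cell lines, Homo sapiens) for cytotoxicity, read by sulforhodamine B assay, with a stated time of 48 h (on this read-out higher numbers stand for weaker inhibition of growth and lower numbers for stronger inhibition of growth), the higher of the two numbers seen so far. Compound 1 `O=C1N=C(N2N=C(c3ccccc3)CC2c2ccc(Cl)cc2)S/C1=C1/C(=O)Nc2ccccc21` gives 190 nM in this assay. Among the compounds with values here, the one measured step between these two, a 410-fold higher number from compound 1 to compound 2 (2.61 log units; beyond the scatter), involves a methoxy in place of hydrogen on an aromatic carbon, a change at a different place in the molecule.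

Compound 3 `COc1ccc(C2=NN(C3=NC(=O)/C(=C4\C(=O)Nc5ccc(Cl)cc54)S3)C(c3ccc(Cl)cc3)C2)cc1` differs from compound 2 by chloro in place of hydrogen on an aromatic carbon. Within the data shown here, no measured step bears on this change: the only step known concerns a different group on a different ring, so it gives no guidance on the size or direction of a chloro substitution here. In this assay the default expectation is therefore a step that stays within the scatter, in either direction.

Compound 3 is thus expected to give about 77500 nM, with a range from 15000 nM to 300000 nM. That estimate corresponds to an expected step of no change at the digits printed from compound 2 to compound 3 (within the scatter), within the scatter.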

Compound 3, concentration for 50% growth inhibition: 190 nM
Estimate against measurement, compound 3: 410-fold (2.61 log units) above, outside the stated range (below it).
By their numbers in this assay, from the lowest: compounds 1 and 3 (each within the scatter of the next); then compound 2.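

In this assay, chloro in place of hydrogen on an aromatic carbon of the six-membered carbon ring, part of a fused system of two rings, gives a large step toward stronger inhibition of growth: a 410-fold lower number from compound 2 to compound 3 (2.61 log units; beyond the scatter). Within the data shown here, the earlier step concerned only the methoxy at a different place, so this is the first sign that this position also strongly affects the read-out, and that a single added chlorine atom can produce a change of this size on a compound carrying the methoxy. Nothing measured here accounts for the size of this step.

As far as these compounds go, whether chloro gives a similar step on a compound without the methoxy remains open. Also open, from the compounds shown here alone, is what fluoro, methyl or an amine would give on the same aromatic carbon.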